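A few compounds are considered here, and "the series" means these few. Any claim that something is new, unique, unknown or untested is made for them only; others in the source may bear on it.

Measured so far in a functional assay on MDA-MB-435 cells (Homo sapiens) for inhibition, read by sulforhodamine B assay, with a stated time of 48 h; on this read-out higher numbers stand for weaker inhibition of growth and lower numbers for stronger inhibition of growth:

- compound 1 `CCOC(=O)C(=Cc1c(-c2ccccc2)[nH]c2ccccc12)C(=O)OCC`: 3400 nM
- compound 2 `O=C(/C(=C\c1c(-c2ccccc2)[nH]c2ccccc12)S(=O)(=O)c1ccccc1)c1ccccc1`: 3900 nM

Two compounds only. In this assay, within the data shown here, compound 2 gives 3900 nM and compound 1 gives 3400 nM; the two values lie within the scatter of each other, so neither compound can be set ahead of the other, and no step between measured compounds is available to calibrate changes.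

Compound 3 `CC(=O)/C(=C\c1c(-c2ccccc2)[nH]c2ccccc12)S(=O)(=O)c1ccccc1` is the next entry. It differs from compound 2 in one place: methyl in place of phenyl on a carbonyl carbon. Nothing in the measured pair bears on this change, and no other substitution at that carbonyl carbon has been tested.

Expectation: a modest loss, with the step from compound 2 to compound 3 estimated at a 1.8-fold higher number from compound 2 to compound 3 (0.25 log units; within the scatter), only somewhat beyond the scatter. Compound 3 is accordingly estimated at 7000 nM in this assay, with a range from 2500 nM to 20000 nM.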

Compound 3, concentration for 50% growth inhibition: 295 nM
For compound 3 the middle estimate is 24-fold (1.38 log units) above the measured one; measured number outside the range, below it.
By their numbers in this assay, from the lowest: compound 3; then compounds 1 and 2 (each within the scatter of the next).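

In this assay, among these compounds, the change from benzoyl to acetyl gives a 13-fold lower number from compound 2 to compound 3 (1.12 log units; beyond the scatter), the first step that lies beyond the scatter. It shows that the group on this carbonyl carbon strongly affects growth inhibition and that the phenyl there is not required, since methyl, with 1 heavy atom in place of 6, gives the lower number. No measurement shown explains the size of this step.

A single change at this carbonyl carbon cannot show whether the trend follows group size or is specific to methyl. Ethyl, a longer alkyl chain, a trifluoromethyl group or an amine at this carbonyl carbon would test this, as would a substituted phenyl, and the result may also differ in other cell lines.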